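The source may hold more compounds than are shown below. What is called first, only, known or untested is meant among the compounds shown, and "the series" means these compounds.

Measured so far:
- compound 1, `Cc1cn([C@@H]2O[C@H](CO[Si](C)(C)C(C)(C)C)[C@@]3(OS(=O)(=O)C=C3NCCC(=O)OCc3ccccc3)[C@H]2O[Si](C)(C)C(C)(C)C)c(=O)n(C)c1=O`. In a functional assay on CCRF-CEM cells (Homo sapiens) (on this read-out higher numbers stand for lower toxicity in this test and lower numbers for higher toxicity in this test), compound 1 gives only a limit of the test, > 250000 nM.
- compound 2, `CC(=O)NC1=CS(=O)(=O)O[C@@]12[C@@H](CO[Si](C)(C)C(C)(C)C)O[C@@H](n1cc(C)c(=O)n(C)c1=O)[C@@H]2O[Si](C)(C)C(C)(C)C`. In this assay compound 2 gives 25700 nM.

Going by the values given here, compound 2 holds the only finite number; the other value is a limit, so compound 2 cannot be ranked against compound 1 beyond the one measured step. That step, an at least 9.7-fold lower number from compound 1 to compound 2 (0.98 log units; beyond the scatter), is known only as a floor because the limit of > 250000 nM in this assay, at which 1 of the 2 values shown sits, caps what compound 1 could show.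

Compound 3, `Cc1cn([C@@H]2O[C@H](CO[Si](C)(C)C(C)(C)C)[C@@]3(OS(=O)(=O)C=C3NCC(=O)O)[C@H]2O[Si](C)(C)C(C)(C)C)c(=O)n(C)c1=O`, keeps the shared core and changes the same amine nitrogen again: carboxymethyl in place of acetyl on an amine nitrogen, that is, acetamido becomes (carboxymethyl)amino. Among the compounds with values here, the only step that bears on it is the one from compound 1 to compound 2, where shortening the chain on that nitrogen lowered the number sharply. Re-extending it with a carboxymethyl group is therefore expected to move this assay back upward, by a step around a 2.7-fold higher number from compound 2 to compound 3 (0.44 log units; beyond the scatter), with a real chance that only a limit is returned. Compound 3 is estimated at 70000 nM, in the range 15000 nM to 250000 nM.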

Compound 3, half-maximal cytotoxic concentration: 65000 nM
Beside the measured number, compound 3's estimate is 1.1-fold (0.03 log units) above it; the measured number falls inside the stated range.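

In this assay, a finite number on this amine nitrogen is not confined to the acetamido group: the change to (carboxymethyl)amino gives a 2.5-fold higher number from compound 2 to compound 3 (0.40 log units; beyond the scatter), so the nitrogen's substituent still moves the read-out when acetyl is gone. Carboxy in place of (benzyloxycarbonyl)methyl on the saturated chain carbon gives an at least 3.8-fold lower number from compound 1 to compound 3 (0.58 log units; beyond the scatter), which places the free carboxylic acid on the lower side of the benzyl ester chain of compound 1. Compound 1 sits at a limit of the test, so this last step is only a floor and its true size stays unknown: the limit of > 250000 nM in this assay, at which 1 of the 3 values shown sits.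

The step to the free acid joins a change in the chain with the loss of the benzyl ester, and a benzyl or methyl ester on the carboxymethyl chain, or a longer chain ending in a carboxylic acid, would be needed to separate the two. The reading of a primary amine at this nitrogen also stays open, as does that of a free hydroxyl in place of either silyl ether, which all the compounds shown retain on the shared core.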